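From chloromethyl to 4-bromophenyl on a carbonyl carbon

This account rests on a few compounds, and the source may have more. Where it says the series, first, only, none or still open, it means among the compounds named here.

In a functional assay on HepG2 cells (Homo sapiens) for cytotoxicity, read by MTT assay (on this read-out higher numbers stand for weaker inhibition and lower numbers for stronger inhibition), compound 3 (`COc1ccc(/C=C/C(=O)c2ccc(OC)c3c2OC(C)(C)C=C3)cc1OC(=O)CCl`) gives 120 nM as the only number shown. Compound 1 (`C#CCOc1cc(/C=C/C(=O)c2ccc(OC)c3c2OC(C)(C)C=C3)ccc1OC`) reads > 10000 nM as a limit of the assay. Compound 2 (`C=CCOc1cc(/C=C/C(=O)c2ccc(OC)c3c2OC(C)(C)C=C3)ccc1OC`) reads > 10000 nM as a limit as well. Compound 4 (`COc1ccc(/C=C/C(=O)c2ccc(OC)c3c2OC(C)(C)C=C3)cc1OC(=O)c1ccc(Br)cc1`) carries 4-bromophenyl in place of chloromethyl on a carbonyl carbon. Two large measured steps bear on this (an at least 83-fold lower number from compound 1 to compound 3 (1.92 log units; beyond the scatter)) and (an at least 83-fold lower number from compound 2 to compound 3 (1.92 log units; beyond the scatter)). Both brought in (chloromethyl)carbonyl, so losing chloromethyl is expected to give back part of that gain, though neither step tests this change directly. The expected step is moderate and toward weaker inhibition (a 7.5-fold higher number from compound 3 to compound 4 (0.88 log units; beyond the scatter)). Compound 4 is estimated at 900 nM with an expected range of 150 nM to 7000 nM in this read-out.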

Compound 4, half-maximal inhibitory concentration: 680 nM
For compound 4 the middle estimate is 1.3-fold (0.12 log units) above the measured one; the measured number falls inside the stated range.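

In this assay the chloromethyl group on the carbonyl carbon can give way to 4-bromophenyl at a modest cost, with a 5.7-fold higher number from compound 3 to compound 4 (0.75 log units; beyond the scatter) as the result. The carbonyl on that oxygen therefore keeps most of its gain without chloromethyl, since allyl gives way to (4-bromophenyl)carbonyl with an at least 14-fold lower number from compound 2 to compound 4 (1.16 log units; beyond the scatter) and propargyl gives way to it with an at least 14-fold lower number from compound 1 to compound 4 (1.16 log units; beyond the scatter) as the reading. Both of these steps start from a limit of the assay: the limit of > 10000 nM in this assay, at which 2 of the 4 values shown sit.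

With only these two groups on the carbonyl carbon, the part played by the bromine cannot be separated from that of the aromatic ring. From the compounds shown here alone, how an unsubstituted phenyl or an aminomethyl group would read there remains open.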